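Taking one methyl off the core of compound 1

The source may report more compounds than this note shows. Statements on the series, on what has been measured and on what is new or still open speak of the compounds shown alone.

- compound 1 `COc1ccc(N(C)c2nc(C)nc3c2nc(C)n3C)cc1` gives 7300 nM
- compound 2 `COc1ccc(Nc2nc(C)nc3c2nc(C)n3C)cc1` gives the limit >= 100000 nM
- compound 3 `COc1ccc(N(C)c2nc(C)nc3c2ncn3C)cc1` is not yet measured

Among the measured compounds shown here, in a functional assay on HMEC-1 cells (Homo sapiens) for inhibition, read by cell counting, with a stated time of 4 days (on this read-out higher numbers stand for weaker inhibition and lower numbers for stronger inhibition), compound 1 gives 7300 nM as the only true number so far. Compound 2 gives >= 100000 nM and that is a limit. Compound 3 differs from compound 1 by hydrogen in place of methyl on an aromatic carbon in one place: hydrogen in place of methyl on an aromatic carbon. For the measured compounds named here, the one measured step, an at least 13-fold higher number from compound 1 to compound 2 (1.13 log units; beyond the scatter), is large but sits on a nitrogen, so it warns that a single methyl can matter without setting a direction for this carbon. The expected change is therefore small and of open direction, estimated as a 1.2-fold lower number from compound 1 to compound 3 (0.09 log units; within the scatter) with wide uncertainty. Compound 3 is estimated at 6000 nM (range 1000 nM to 30000 nM).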

Compound 3, half-maximal inhibitory concentration: 9200 nM
Compound 3: middle estimate off by 1.5-fold (0.19 log units), on the low side; measured number inside the range.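

Replacing the methyl on the aromatic carbon between two ring nitrogen atoms with hydrogen gives a 1.3-fold higher number from compound 1 to compound 3 (0.10 log units; within the scatter) in this assay. This methyl can therefore go without a clear change in the read-out, unlike the methyl on the nitrogen, whose removal gives compound 2, so the two methyl groups do not count alike. Nothing measured here explains that contrast.

Only hydrogen and methyl appear on this carbon among the compounds shown. As far as these compounds go, how an ethyl group, an amine or a carboxylic acid there would behave remains open.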